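Benzoyl in place of triazolylmethyl on the benzyl arm

The source may report more compounds than this note shows. Statements on the series, on what has been measured and on what is new or still open speak of the compounds shown alone.

Values in a functional assay on CHO.K1 cells for antagonist activity at prostaglandin D2 receptor 2 (Homo sapiens), read by GTPgammaS binding, with a stated time of 1 h; on this read-out higher numbers stand for weaker inhibition and lower numbers for stronger inhibition:

Compound 1 `Cc1c(Cc2ccccc2S(=O)(=O)c2cccc(Cl)c2)c2c(n1CC(=O)O)CCNC2=O`: 4 nM
Compound 2 `Cc1c(Cc2ccccc2S(=O)(=O)c2ccc(Cl)cc2)c2c(n1CC(=O)O)CCNC2=O`: 8.5 nM
Compound 3 `Cc1c(Cc2ccccc2Cn2ccnn2)c2c(n1CC(=O)O)CCNC2=O`: 800 nM

Compound 3 carries the highest number of the three. Its distance to the others is set by a 200-fold higher number from compound 1 to compound 3 (2.30 log units; beyond the scatter) and by a 94-fold higher number from compound 2 to compound 3 (1.97 log units; beyond the scatter); both steps lie beyond the scatter, so compound 3 is the weakest inhibitor measured here. Between compound 1 and compound 2 the step is a 2.1-fold higher number from compound 1 to compound 2 (0.33 log units; beyond the scatter), modest.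

Compound 4 `Cc1c(Cc2ccccc2C(=O)c2ccccc2)c2c(n1CC(=O)O)CCNC2=O` differs from compound 3 by benzoyl in place of (1H-1,2,3-triazol-1-yl)methyl on an aromatic carbon. Among the compounds with values here, no measured pair exchanges the triazolylmethyl for a benzoyl. Within the data shown here, the steps that bear on it are the two that remove the triazolylmethyl in favour of an aryl-bearing group on the same carbon, giving a 200-fold higher number from compound 1 to compound 3 (2.30 log units; beyond the scatter) and a 94-fold higher number from compound 2 to compound 3 (1.97 log units; beyond the scatter) when read in the other direction. Both are large; the entering benzoyl shares an aromatic ring with the sulfonyl groups of compound 1 and compound 2, but not the sulfonyl link, so a smaller gain is expected. The expected step is a 20-fold lower number from compound 3 to compound 4 (1.30 log units; beyond the scatter), a lower number. Compound 4 is estimated at 40 nM, within 8 nM to 250 nM.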

Compound 4, half-maximal inhibitory concentration: 810 nM
Compound 4: the middle estimate sits 20-fold (1.31 log units) below what was measured; the whole stated range lies below it.
By their numbers in this assay, from the lowest: compound 1; then compound 2; then compounds 3 and 4 (each within the scatter of the next).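

In this assay, benzoyl and (1H-1,2,3-triazol-1-yl)methyl on this aromatic carbon cannot be told apart, with a 1.0-fold higher number from compound 3 to compound 4 (0.01 log units; within the scatter). A six-membered aromatic ring of carbon only in the entering group does not, in compound 4, reach the level of the sulfonyl compounds: the steps stay large, with a 95-fold higher number from compound 2 to compound 4 (1.98 log units; beyond the scatter) and a 200-fold higher number from compound 1 to compound 4 (2.31 log units; beyond the scatter), though in both pairs the carbonyl link and the loss of chlorine change together. Nothing measured here accounts for these steps.

The compounds shown leave apart the contributions of the sulfonyl link and the chlorine, which an unsubstituted phenylsulfonyl or a chlorobenzoyl group on the same carbon would separate. As far as these compounds go, whether a sulfonamide link would behave like the sulfonyl or like the carbonyl also remains open.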